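One small measured step, one new group

This account rests on a few compounds, and the source may have more. Where it says the series, first, only, none or still open, it means among the compounds named here.

- Compound 1 `COc1cccc(Oc2cccc(CN3CCC(n4cc(C)c(=O)[nH]c4=O)CC3)c2)c1` gives 25300 nM
- Compound 2 `Cc1cn(C2CCN(Cc3cccc(Oc4cccc(Cl)c4)c3)CC2)c(=O)[nH]c1=O` gives 21000 nM

In an ADME assay on MRC5 cells (Homo sapiens) for cytotoxicity, read by fluorescence and resazurin assay, with a stated time of 3 days (a higher number here means a weaker inhibitor, a lower number a stronger inhibitor), compound 2 gives 21000 nM and sits level with compound 1 within the scatter. Compound 3 `Cc1cn(C2CCN(Cc3cccc(Oc4cccc(OC(F)(F)F)c4)c3)CC2)c(=O)[nH]c1=O` keeps the shared core but carries trifluoromethoxy in place of chloro on an aromatic carbon. Within the data shown here, only one measured step bears on this change, chloro in place of methoxy on an aromatic carbon (a 1.2-fold lower number from compound 1 to compound 2 (0.08 log units; within the scatter)), and it stays within the scatter, so no step beyond the scatter is expected in this assay here. The estimated step is small (a 1.1-fold lower number from compound 2 to compound 3 (0.04 log units; within the scatter)). The expected value for compound 3 is 19000 nM (estimated range 9500 nM to 38000 nM).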

Compound 3, half-maximal inhibitory concentration: 5260 nM
Compound 3: the middle estimate sits 3.6-fold (0.56 log units) above what was measured; the measured number lies below the stated range.
By their numbers in this assay, from the lowest: compound 3; then compounds 2 and 1 (each within the scatter of the next).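

The earlier pair suggested that this aromatic carbon tolerates a change of group, since chloro and methoxy sit level within the scatter. Trifluoromethoxy shows otherwise: it gives a 4.0-fold lower number from compound 2 to compound 3 (0.60 log units; beyond the scatter) in this assay, and replacing methyl with trifluoromethyl on the oxygen gives a 4.8-fold lower number from compound 1 to compound 3 (0.68 log units; beyond the scatter), so the number at this position can move beyond the scatter. Nothing available explains why this group stands apart.

Going by these compounds, it remains open whether a trifluoromethyl group attached directly to the ring, or a nitrile, would give a similar step. On these data alone, whether an amine at this carbon would shift the number also remains unknown.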